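This account rests on a few compounds, and the source may have more. Where it says the series, first, only, none or still open, it means among the compounds named here.

Compound 1, `CCOC(=O)c1sc(-c2cccc(NC(=O)c3ccc(C(F)(F)F)cc3)c2)nc1Nc1ccc(N2CCN(C)CC2)cc1`, is the reference point of this small set. In a functional assay on Raji cells (Homo sapiens) for antiproliferative activity, read by CCK-8 assay, with a stated time of 72 h, tested at 40 uM (on this read-out lower numbers stand for less inhibition and higher numbers for more inhibition at the one concentration tested (going by the name of the read-out)), compound 1 gives 33%, the highest of the three numbers recorded. Its two neighbours differ from it only at the amide end. Compound 2, `CCOC(=O)c1sc(-c2cccc(NC(=O)c3ccc(F)cc3)c2)nc1Nc1ccc(N2CCN(C)CC2)cc1`, gives 16.8%, and the step of a number 16.2 percentage points lower from compound 1 to compound 2 (beyond the scatter) is a modest drop. Compound 3, `CCOC(=O)c1sc(-c2cccc(NC(=O)c3ccc(F)c(Cl)c3)c2)nc1Nc1ccc(N2CCN(C)CC2)cc1`, gives 20.7%, and the step of a number 12.3 percentage points lower from compound 1 to compound 3 (beyond the scatter) is also a modest drop. Between compound 2 and compound 3 the step of a number 3.9 percentage points higher from compound 2 to compound 3 (within the scatter) stays within the scatter.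

Compound 4, `CN1CCN(c2ccc(Nc3nc(-c4cccc(NC(=O)c5ccc(C(F)(F)F)cc5)c4)sc3C(N)=O)cc2)CC1`, changes compound 1 at the other end of the molecule: amino in place of ethoxy on a carbonyl carbon. Among the measured compounds shown here, none of the measured steps touches this position, so they bear on it only indirectly, by showing that single changes so far moved the read-out by modest amounts. Without direct evidence, the expectation for the step of a number 3 percentage points lower from compound 1 to compound 4 (within the scatter) is a small change in either direction, quite possibly inside the scatter. Compound 4 is therefore estimated at 30%, with a range from 10% to 50%.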

Compound 4, a percentage reported as inhibition, at one concentration (the size of the read-out at that concentration, not a potency): 91.9%
Estimate against measurement, compound 4: 61.9 percentage points below; measured number above the stated range.
By their numbers in this assay, from the lowest: compounds 2 and 3 (each within the scatter of the next); then compound 1; then compound 4.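

The ethoxycarbonyl to carbamoyl change gives a number 58.9 percentage points higher from compound 1 to compound 4 (beyond the scatter) in this assay, so this position matters far more than the amide end did, where the changes gave a number 16.2 percentage points lower from compound 1 to compound 2 (beyond the scatter) and a number 12.3 percentage points lower from compound 1 to compound 3 (beyond the scatter). The swap replaces a group of 3 heavy atoms and 0 hydrogen-bond donors with one of 1 heavy atom and 1 hydrogen-bond donor, and this single pair cannot show which of these differences counts, if either does. Nothing available here accounts for the size of the rise.

Going by these compounds, it remains open whether other groups on this carbonyl carbon, such as methylamino, hydroxyl or a longer alkoxy chain like propoxy, would keep the high reading. On these data alone, it is also open whether amino in place of ethoxy would raise the reading to a similar degree with the fluoro amide end of compound 2 or the chloro and fluoro amide end of compound 3.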